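Swapping the Aryl Group on a Shared Core

A few compounds are considered here, and "the series" means these few. Any claim that something is new, unique, unknown or untested is made for them only; others in the source may bear on it.

Compound 1 `O=C1O/C(=C\Cn2cc(-c3ccc(Br)cc3)nn2)C(OCc2ccccc2)=C1OCc1ccccc1` gives > 100000 nM in a functional assay on HCT-116 cells (Homo sapiens) for antiproliferative activity, read by MTT assay, with a stated time of 72 h (on this read-out lower numbers stand for stronger inhibition and higher numbers for weaker inhibition), which is a limit of the assay.
Compound 2 `O=C1O[C@H]([C@@H](O)Cn2cc(-c3ccc(Br)cc3)nn2)C(OCc2ccccc2)=C1OCc1ccccc1` gives 9420 nM in this assay.
Compound 3 `CC(C)(C)OC(=O)N1CCN(C(=S)SCc2cn(C[C@H](O)[C@H]3OC(=O)C(OCc4ccccc4)=C3OCc3ccccc3)nn2)CC1` gives > 100000 nM in this assay, again a limit of the assay.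

Compound 2 stands as the only number shown; the other two values sit at the limit of > 100000 nM in this assay, at which 2 of the 3 values shown sit. Compound 4 `COc1ccccc1-c1cn(C[C@H](O)[C@H]2OC(=O)C(OCc3ccccc3)=C2OCc2ccccc2)nn1` differs from compound 2 in one place: 2-methoxyphenyl in place of 4-bromophenyl on an aromatic carbon. Going by the values given here, no measured pair of compounds shows this change, so the size of its step is open. A step a little beyond the scatter, toward weaker inhibition, is expected, with wide uncertainty, and the step from compound 2 to compound 4 is estimated as a 1.9-fold higher number from compound 2 to compound 4 (0.28 log units; within the scatter). Compound 4 is expected to give about 18000 nM, between 4500 nM and 70000 nM.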

Compound 4, half-maximal inhibitory concentration: > 100000 nM
Compound 4 ended at the assay's limit (the forecaster's own chance of this, stated with the estimate: 25%); at least 5.5-fold (0.74 log units) between middle value and limit.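

This position is sensitive to the aryl group it carries: in this assay, 2-methoxyphenyl in place of 4-bromophenyl gives an at least 10-fold higher number from compound 2 to compound 4 (1.02 log units; beyond the scatter). For compound 4, the value > 100000 nM is a limit of the assay, not a number. Compound 2 therefore remains the only compound here with a measured number, and the others sit at the ceiling: the limit of > 100000 nM in this assay, at which 3 of the 4 values shown sit.

The compounds shown cannot separate the effect of the methoxy group from that of removing the bromine. Going by these compounds, it also remains open whether a plain phenyl or a 4-methoxyphenyl group at this position would give a measurable value.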